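Two Chlorines in Place of One Fluorine on the Ring

The compounds below may be only part of what the source reports. "The series", "measured", "known", "first", "only" and "open" are said of these compounds alone.

Compound 2 `COc1cc2c(Oc3ccc(NC(=O)c4cn(-c5ccccc5F)nn4)cc3F)ccnc2cc1OCCCN1CCCCC1` and compound 1 `COc1cc2c(Oc3ccc(NC(=O)c4cn(-c5ccccc5C)nn4)cc3F)ccnc2cc1OCCCN1CCCC1` were both tested in a functional assay on NCI-H460 cells (Homo sapiens) for cytotoxicity, read by MTT assay, with a stated time of 72 h; a lower number here means a stronger inhibitor, a higher number a weaker inhibitor. Compound 2 gives 210 nM, the lower of the two numbers, while compound 1 gives 1260 nM, a gap beyond the usual scatter. These two differ in more than one place, so no single step can be read from them. Compound 3 `COc1cc2c(Oc3ccc(NC(=O)c4cn(-c5c(Cl)cccc5Cl)nn4)cc3F)ccnc2cc1OCCCN1CCCCC1` has not yet been measured in this assay; it differs from compound 2 by 2,6-dichlorophenyl in place of 2-fluorophenyl on an aromatic nitrogen. For the measured compounds named here, with no measured step of this kind to lean on, the expected step from compound 2 to compound 3 is a 1.9-fold higher number from compound 2 to compound 3 (0.28 log units; within the scatter), a change that may stay within the scatter. Compound 3 is therefore estimated at 400 nM, with a range from 120 nM to 1500 nM.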

Compound 3, half-maximal inhibitory concentration: 280 nM
Compound 3: the middle estimate sits 1.4-fold (0.15 log units) above what was measured; measured number inside the range.
By their numbers in this assay, from the lowest: compounds 2 and 3 (each within the scatter of the next); then compound 1.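

In this assay the 2,6-dichlorophenyl group in place of 2-fluorophenyl on the aromatic nitrogen gives a 1.3-fold higher number from compound 2 to compound 3 (0.12 log units; within the scatter) and so leaves the number within the scatter. This is the first step shown that changes this position alone. Compound 1 differs from compound 2 in more than one place. This step shows that this position tolerates two chlorines in place of one fluorine in these cells. Still open, on these data alone, is how a phenyl group carrying an amine or a carboxylic acid would behave here. Nothing measured here explains the result.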